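Pyridin-2-yl in place of 3,4-dimethoxyphenyl at a limit

A few compounds are considered here, and "the series" means these few. Any claim that something is new, unique, unknown or untested is made for them only; others in the source may bear on it.

Compound 1 `COc1ccc(/C=C2\S/C(=N\c3ccccc3)N(Cc3ccco3)C2=O)cc1OC` gives > 250000 nM as a limit
Compound 2 `O=C1/C(=C/c2ccc(O)cc2)S/C(=N\c2ccccc2)N1Cc1ccco1` gives > 250000 nM as a limit

In a toxicity assay on CHO cells (Cricetulus griseus) for cytotoxicity, read by MTT assay, with a stated time of 72 h (on this read-out lower numbers stand for stronger inhibition and higher numbers for weaker inhibition), compound 1 stands at > 250000 nM as a limit of the assay and not a number. Both measured compounds rest on the limit of > 250000 nM in this assay, at which 2 of the 2 values shown sit, and give no number. Compound 3 `O=C1/C(=C/c2ccccn2)S/C(=N\c2ccccc2)N1Cc1ccco1` carries pyridin-2-yl in place of 3,4-dimethoxyphenyl (pyridin-2-yl in place of 3,4-dimethoxyphenyl on a double-bonded chain carbon bound to a double-bonded ring carbon) on a double-bonded chain carbon bound to a double-bonded ring carbon. Going by the values given here, the one measured step at that place (a step that the two limits leave unreadable from compound 1 to compound 2) offers no size to carry over. No step beyond the scatter is therefore expected in this assay for this change. The estimated step reads a number no higher from compound 1 to compound 3 (the limit leaves the size open) on that basis. Compound 3 is estimated at 250000 nM with an expected range from 100000 nM to 400000 nM for its value.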

Compound 3, half-maximal inhibitory concentration: > 250000 nM
Compound 3: only a limit was reported; the forecaster's own chance of this, stated with the estimate: 80%; the middle value lies on the limit itself.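

Compound 1, compound 2 and compound 3 each give only a limit in this assay and not a number, so no step among them can be read: the limit of > 250000 nM in this assay, at which 3 of the 3 values shown sit.

On these data alone, how these three compounds would rank against one another in this assay stays open.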